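Alkyne chain length on the sulfonamide series: compound 4

A few compounds are considered here, and "the series" means these few. Any claim that something is new, unique, unknown or untested is made for them only; others in the source may bear on it.

Measured so far in a functional assay on A-375 cells (Homo sapiens) for antiproliferative activity, read by trypan blue exclusion, with a stated time of 48 h, tested at 5 uM; a higher number here means a weaker effect of the compound at the concentration tested, a lower number a stronger effect:

compound 1 `CCCCCCC#Cc1ccc(S(=O)(=O)Nc2cccc(-c3csc(NC(C)=O)n3)c2)cc1` gives 12.8%
compound 2 `CCCCC#Cc1ccc(S(=O)(=O)Nc2cccc(-c3csc(NC(C)=O)n3)c2)cc1` gives 9.3%
compound 3 `CC(=O)Nc1nc(-c2cccc(NS(=O)(=O)c3ccc(C#CC4CCCCC4)cc3)c2)cs1` gives 1.2%

Compound 1 has the highest of the three numbers in this assay . Its neighbour compound 2 lies within the scatter of it, the step being a number 3.5 percentage points lower from compound 1 to compound 2 (within the scatter). Compound 3 lies furthest away, with a number 11.6 percentage points lower from compound 1 to compound 3 (beyond the scatter). Between compound 2 and compound 3 the step is a number 8.1 percentage points lower from compound 2 to compound 3 (within the scatter).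

Compound 4 `CCCCCCCCC#Cc1ccc(S(=O)(=O)Nc2cccc(-c3csc(NC(C)=O)n3)c2)cc1` is still to be measured. It differs from compound 1 by ethyl in place of hydrogen on a saturated chain carbon, six bonds along the chain from a triple-bonded carbon, so the chain on the triple-bonded carbon grows from hexyl to octyl. The step that bears on this is the one in the opposite direction, from hexyl to butyl, where a number 3.5 percentage points lower from compound 1 to compound 2 (within the scatter) stayed within the scatter. Removing two chain carbons moved the number little, so adding two is expected to move it little as well; the only hint of direction is that the longer chain in compound 1 gave the higher of the two numbers, which is not beyond the scatter. The expected step is therefore a number 1.2 percentage points higher from compound 1 to compound 4 (within the scatter), that is none beyond the scatter.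

The estimate for compound 4 in this assay is 14%, with a range from 5% to 26%.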

Compound 4, a percentage reported as activity, at one concentration (the size of the read-out at that concentration, not a potency): 8.9%
Compound 4: the middle estimate sits 5.1 percentage points above what was measured; the range from low to high includes it.
By their numbers in this assay, from the lowest: compounds 3, 4, 2 and 1 (each within the scatter of the next, the first and the last beyond it).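

In this assay, growing the chain on the triple-bonded carbon from hexyl to octyl gives a number 3.9 percentage points lower from compound 1 to compound 4 (within the scatter), and going from butyl to octyl gives a number 0.4 percentage points lower from compound 2 to compound 4 (within the scatter), so the butyl, hexyl and octyl chains cannot be told apart here and show no trend with chain length at this position. Octyl is also not set apart from cyclohexyl on the triple-bonded carbon, with a number 7.7 percentage points higher from compound 3 to compound 4 (within the scatter), which leaves hexyl as the only open chain shown that lies beyond the scatter of cyclohexyl, and so the case for the ring over open chains is weak. No measurement on hand offers an explanation for any of these steps.

As far as these compounds go, it remains open how a methyl, a phenyl, or a chain carrying an amine or a carboxylic acid on the triple-bonded carbon would read in this assay. Also open, from the compounds shown here alone, is whether the butyl, hexyl, octyl and cyclohexyl compounds, all read at a single concentration, would separate at a lower concentration or across a range of concentrations.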